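The compounds below may be only part of what the source reports. "The series", "measured", "known", "first", "only" and "open" are said of these compounds alone.

Two compounds with a shared core have numbers in a functional assay on PC-3 cells (Homo sapiens) for inhibition, read by MTT assay, with a stated time of 72 h; a lower number here means a stronger inhibitor, a higher number a weaker inhibitor. Compound 1 `Cc1ccc(-n2cc(CNC(=O)c3cccc4c3cnn4C(C)C)nn2)c(C)c1` gives 10600 nM in this assay, and compound 2 `CC(C)n1ncc2c(C(=O)NCc3cn(Cc4ccccc4)nn3)cccc21` gives 4420 nM. Within the data shown here, the one step between them, a 2.4-fold lower number from compound 1 to compound 2 (0.38 log units; beyond the scatter), makes compound 2 the lower of the two numbers in this assay, with compound 1 the nearest measured neighbour. Compound 3 `CC(C)n1ncc2c(C(=O)NCc3cn(Cc4ccc(C(F)(F)F)cc4)nn3)cccc21` is not yet measured and differs from compound 2 by trifluoromethyl in place of hydrogen on an aromatic carbon. No measured step touches this position: the only step shown exchanges the whole group on the aromatic nitrogen, so the measured pair says nothing about adding to that benzyl. Without a guiding step, the expected change in this assay is none beyond the scatter, so the estimate for a 1.1-fold lower number from compound 2 to compound 3 (0.04 log units; within the scatter) is a small step. Compound 3 is therefore expected to give about 4000 nM in this assay, with a range from 1500 nM to 12000 nM.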

Compound 3, half-maximal inhibitory concentration: 23900 nM
Compound 3: the middle estimate sits 6.0-fold (0.78 log units) below what was measured; measured number above the stated range.
By their numbers in this assay, from the lowest: compound 2; then compound 1; then compound 3.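

In this assay the aromatic carbon para to a large group in compound 2 proves sensitive to substitution: trifluoromethyl in place of hydrogen there gives a 5.4-fold higher number from compound 2 to compound 3 (0.73 log units; beyond the scatter) and thus weaker inhibition, a change beyond the scatter. Among these compounds, the earlier step exchanged the whole group on the aromatic nitrogen, so it showed only that this group could be swapped, and it gave no reading of a substituent on the six-membered aromatic ring itself. This step shows that a single addition to that ring, of 4 heavy atoms with no hydrogen-bond donors or acceptors and no net charge, is enough to shift the number.

Whether this holds only for trifluoromethyl or for other groups at this carbon remains open, as the compounds shown include no fluorine atom, methoxy group or nitrile there. Nothing available here bears on the reason for the rise.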